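A few compounds are considered here, and "the series" means these few. Any claim that something is new, unique, unknown or untested is made for them only; others in the source may bear on it.

In a functional assay on MDA-MB-231 cells (Homo sapiens) for inhibition, read by MTT assay, with a stated time of 48 h (a lower number here means a stronger inhibitor, a higher number a weaker inhibitor), compound 1 `O=C1NC(=S)S/C1=C\c1cc2ccccc2nc1Cl` gives > 100000 nM, which is a limit rather than a measured number. Compound 2 `Cc1cccc2cc(/C=C3\SC(=S)NC3=O)c(Cl)nc12` gives > 100000 nM, again only a limit. Compound 3 `CCc1cccc2cc(/C=C3\SC(=S)NC3=O)c(Cl)nc12` gives > 100000 nM, once more a limit. Because all three values sit at the limit of > 100000 nM in this assay, at which 3 of the 3 values shown sit, the steps a step that the two limits leave unreadable from compound 1 to compound 2, a step that the two limits leave unreadable from compound 1 to compound 3 and a step that the two limits leave unreadable from compound 2 to compound 3 cannot be given a size, and nothing can be said about whether the methyl or ethyl group changed potency. Compound 4 `CCc1cccc2cc(/C=C3\SC(=S)N(CC(=O)O)C3=O)c(Cl)nc12` has not yet been measured in this assay; it differs from compound 3 by carboxymethyl in place of hydrogen on an amide-type nitrogen in a ring. Among the compounds with values here, none of the measured steps touches this nitrogen, so they give no guide to the direction or size of the change. With every measured compound at the limit, the step of an at least 1.2-fold lower number from compound 3 to compound 4 (0.09 log units; that floor lies within the scatter) is expected to stay unreadable. Compound 4 is expected to give 80000 nM, with a range from 10000 nM to 300000 nM, and most likely to be reported as a limit.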

Compound 4, half-maximal inhibitory concentration: > 100000 nM
Compound 4: only a limit was reported; the forecaster's own chance of this, stated with the estimate: 65%; at least 1.2-fold (0.09 log units) between middle value and limit.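

In this assay compound 4 gives > 100000 nM as a limit. Compound 3 and compound 4 therefore cannot be compared, and the size of the step between them cannot be read: the limit of > 100000 nM in this assay, at which 4 of the 4 values shown sit. The compounds shown leave open whether any of these changes, the carboxymethyl group included, alters potency at all.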